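From isopropylsulfonyl to (pyrrolidin-1-yl)carbonyl

The source may report more compounds than this note shows. Statements on the series, on what has been measured and on what is new or still open speak of the compounds shown alone.

Compound 1 `COC(=O)N1C[C@H](NC(=O)c2ccc(-n3ccccc3=O)cc2)[C@H](NC(=O)c2ccc(Cl)s2)C1`: > 100000 nM
Compound 2 `CC(C)S(=O)(=O)N1C[C@H](NC(=O)c2ccc(-n3ccccc3=O)cc2)[C@H](NC(=O)c2ccc(Cl)s2)C1`: > 100000 nM

Both compounds were tested in an ADME assay on HEK293 cells (Homo sapiens) for cytotoxicity; a higher number here means a weaker inhibitor, a lower number a stronger inhibitor. In this assay compound 2 gives > 100000 nM, which is a limit of the assay and not a number. Compound 1 is also recorded only as a limit, so the evidence so far is the limit of > 100000 nM in this assay, at which 2 of the 2 values shown sit.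

Compound 3 `O=C(N[C@H]1CN(C(=O)N2CCCC2)C[C@H]1NC(=O)c1ccc(Cl)s1)c1ccc(-n2ccccc2=O)cc1` keeps the shared core and differs from compound 2 in one group: (pyrrolidin-1-yl)carbonyl in place of isopropylsulfonyl on an amine nitrogen in a ring. In short, (pyrrolidin-1-yl)carbonyl comes in place of isopropylsulfonyl on an amine nitrogen in a ring.

Among the compounds with values here, the one measured step at this nitrogen is a step that the two limits leave unreadable from compound 1 to compound 2. It therefore gives no size to carry over, and no shift beyond the scatter is expected in this assay, in either direction. Compound 3 is expected to read about 100000 nM, with an estimated range of 40000 nM to 200000 nM, most likely reported as a limit again. The expected change is a number no higher from compound 2 to compound 3 (the limit leaves the size open).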

Compound 3, half-maximal inhibitory concentration: > 100000 nM
Compound 3 gave a limit, no number; the forecaster's own chance of this, stated with the estimate: 85%; the middle value sits exactly at the limit.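

In this assay compound 3 gives > 100000 nM, which is a limit of the assay and not a number, so no new step can be read among compound 1, compound 2 and compound 3. The compounds shown leave open whether the groups on this ring nitrogen differ at all in this assay.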